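Swapping tert-butyl for iodo in a small series

The source may report more compounds than this note shows. Statements on the series, on what has been measured and on what is new or still open speak of the compounds shown alone.

Three compounds share one core and differ in a single group on an aromatic carbon: compound 1 (`c1cc(C2CCCCC2)ccc1NC1=NCCO1`), compound 2 (`c1ccc(-c2ccc(NC3=NCCO3)cc2)cc1`) and compound 3 (`CC(C)(C)c1ccc(NC2=NCCO2)cc1`). In a functional assay on M21 cells (Homo sapiens) for inhibition, read by sulforhodamine B assay, with a stated time of 48 h (a higher number here means a weaker inhibitor of growth, a lower number a stronger inhibitor of growth), compound 1 gives 17800 nM and compound 2 gives 8800 nM while compound 3 gives 2400 nM as the lowest number of the three, with its steps to both others beyond the scatter.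

The next compound, compound 4 (`Ic1ccc(NC2=NCCO2)cc1`), keeps the core and carries iodo in place of tert-butyl on an aromatic carbon. Going by the values given here, no measured compound carries iodo, so the evidence is only indirect. Three steps at this same place bear on the change: a 2.0-fold lower number from compound 1 to compound 2 (0.31 log units; beyond the scatter) and a 3.7-fold lower number from compound 2 to compound 3 (0.56 log units; beyond the scatter) and a 7.4-fold lower number from compound 1 to compound 3 (0.87 log units; beyond the scatter) and each of them is modest. Compound 3 already holds the lowest number at 2400 nM and none of these steps is large, so a small rise in this assay is expected, perhaps one that stays within the scatter. The expected step is a 1.5-fold higher number from compound 3 to compound 4 (0.16 log units; within the scatter) in this estimate. Compound 4 is estimated at 3500 nM with an expected range of 1300 nM to 10000 nM in this measurement.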

Compound 4, concentration for 50% growth inhibition: 2000 nM
Estimate against measurement, compound 4: 1.8-fold (0.24 log units) above; the measured number falls inside the stated range.
By their numbers in this assay, from the lowest: compounds 4 and 3 (each within the scatter of the next); then compound 2; then compound 1.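

In this assay, iodo and tert-butyl cannot be told apart at this place, with a 1.2-fold lower number from compound 3 to compound 4 (0.08 log units; within the scatter) even though a single iodine atom stands in for a group of 4 heavy atoms, so the tert-butyl group itself is not required to reach this level of growth inhibition. Iodo also stays clear of the two groups that carry a ring, with a 4.4-fold lower number from compound 2 to compound 4 (0.64 log units; beyond the scatter) and an 8.9-fold lower number from compound 1 to compound 4 (0.95 log units; beyond the scatter) in this comparison, so among these four compounds both groups without a ring give lower numbers than phenyl and cyclohexyl, with no compound going against this. Nothing measured here gives a reason why two such different groups match or why the ring-bearing groups fall behind them.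

Going by these compounds, the four compounds sample only iodo, tert-butyl, phenyl and cyclohexyl at this place, so it stays open how another halogen such as chloro, a methoxy group or an amine would compare. On these data alone, it is also open whether any group here could give a number clearly lower than those of compound 3 and compound 4, or whether these two mark the best this position allows.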